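The source may report more compounds than this note shows. Statements on the series, on what has been measured and on what is new or still open speak of the compounds shown alone.

Of the compounds shown here, three sharing one core have been measured in a functional assay on U-87MG ATCC cells (Homo sapiens) for inhibition, read by MTT assay, with a stated time of 72 h; on this read-out lower numbers stand for stronger inhibition and higher numbers for weaker inhibition. Compound 1 `COc1cc2c(Oc3ccc(NC(=O)c4nn(-c5ccccc5OC(F)(F)F)c(=O)cc4C)cc3F)ccnc2cc1OCCCN1CCCC1` gives 1280 nM in this assay, compound 2 `COc1cc2c(Oc3ccc(NC(=O)c4nn(-c5ccccc5OC(F)(F)F)c(=O)cc4C)cc3F)ccnc2cc1OCCCN1CCCCC1` gives 1300 nM, and compound 3 `COc1cc2c(Oc3ccc(NC(=O)c4nn(-c5ccccc5OC(F)(F)F)c(=O)cc4C)cc3F)ccnc2cc1OCCCN1CCN(C)CC1` gives 1440 nM. Compound 2 thus stands second highest of the three numbers, with compound 1 nearest and compound 3 furthest, and all three values lie within the scatter of one another: a 1.0-fold higher number from compound 1 to compound 2 (0.01 log units; within the scatter), a 1.1-fold higher number from compound 1 to compound 3 (0.05 log units; within the scatter) and a 1.1-fold higher number from compound 2 to compound 3 (0.04 log units; within the scatter) are each too small to count as a change.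

Compound 4 `COc1cc2c(Oc3ccc(NC(=O)c4nn(-c5ccc(Cl)cc5Cl)c(=O)cc4C)cc3F)ccnc2cc1OCCCN1CCCCC1` has not been measured. It differs from compound 2 in a single place: 2,4-dichlorophenyl in place of 2-(trifluoromethoxy)phenyl on an aromatic nitrogen. Among the measured compounds shown here, none of the measured steps touches that position; they all exchange the amine at the end of the chain, three bonds along from the oxygen on the aromatic ring, and every one of them stayed within the scatter. So there is no measured step from which the size or direction of the step from compound 2 to compound 4 in this assay can be read, and the expectation can rest only on the observation that the three measured compounds cluster closely. On that basis compound 4 is expected to give about 1300 nM in this assay, within a broad range from 400 nM to 4500 nM, which means an estimated step of no change at the digits printed from compound 2 to compound 4 (within the scatter).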

Compound 4, half-maximal inhibitory concentration: 1800 nM
Compound 4: middle estimate off by 1.4-fold (0.14 log units), on the low side; the measured number falls inside the stated range.
By their numbers in this assay, from the lowest: compounds 1, 2, 3 and 4 (each within the scatter of the next).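

In this assay, among the compounds shown here, the first measured change on the aromatic nitrogen, 2,4-dichlorophenyl in place of 2-(trifluoromethoxy)phenyl, gives a 1.4-fold higher number from compound 2 to compound 4 (0.14 log units; within the scatter). For the compounds shown here, the earlier steps exchanged only the amine at the end of the chain, so this is the first sign that the aryl group on the aromatic nitrogen can also be exchanged without a change beyond the scatter, at least for this pair on the piperidin-1-yl background. That holds even though the exchange replaces a group of 11 heavy atoms and 1 hydrogen-bond acceptor with one of 8 heavy atoms and 0 hydrogen-bond acceptors, and no measurement is available that bears on why the numbers stay so close.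

Going by these compounds, with a single exchange at this position, it remains open whether an unsubstituted phenyl, a 4-fluorophenyl or a non-aromatic group such as cyclohexyl on the same nitrogen would also stay within the scatter. On these data alone, it is equally open whether 2,4-dichlorophenyl would behave the same way alongside the pyrrolidin-1-yl or 4-methylpiperazin-1-yl amine at the end of the chain.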